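A few compounds are considered here, and "the series" means these few. Any claim that something is new, unique, unknown or untested is made for them only; others in the source may bear on it.

Measured so far:
- compound 1, `COc1cc(-c2nn(-c3cccc(NC(=O)c4ccc(Cl)c(C(F)(F)F)c4)c3)cc2-c2ccncc2)ccc1Cl`: 8040 nM
- compound 2, `O=C(Nc1cccc(-n2cc(-c3ccncc3)c(-c3ccc(Cl)c(O)c3)n2)c1)Nc1cc(C(F)(F)F)cc(C(F)(F)F)c1`: 849 nM

In a functional assay on OVCAR-4 cells (Homo sapiens) for inhibition, read by sulforhodamine B assay, with a stated time of 48 h (a lower number here means a stronger inhibitor of growth, a higher number a weaker inhibitor of growth), compound 1 gives the higher of the two numbers, and compound 2 gives the lower one, a gap beyond the usual scatter. Compound 3, `COc1cc(-c2nn(-c3cccc(NC(=O)Nc4cccc(C(F)(F)F)c4)c3)cc2-c2ccncc2)ccc1Cl`, differs from compound 1 in one place: (3-(trifluoromethyl)phenyl)amino in place of 4-chloro-3-(trifluoromethyl)phenyl on a carbonyl carbon. Going by the values given here, no measured pair shows this change on its own. Because compound 2, which also carries an amino group on its carbonyl carbon, gives 849 nM, a lower number is expected for compound 3, a step of a 3.2-fold lower number from compound 1 to compound 3 (0.51 log units; beyond the scatter) beyond the scatter. Compound 3 is estimated at 2500 nM, within 800 nM to 8000 nM.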

Compound 3, concentration for 50% growth inhibition: 1100 nM
Beside the measured number, compound 3's estimate is 2.3-fold (0.36 log units) above it; low and high end bracket the measured number.
By their numbers in this assay, from the lowest: compounds 2 and 3 (each within the scatter of the next); then compound 1.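

In this assay the group on the carbonyl carbon proves to matter: (3-(trifluoromethyl)phenyl)amino in place of 4-chloro-3-(trifluoromethyl)phenyl gives a 7.3-fold lower number from compound 1 to compound 3 (0.86 log units; beyond the scatter) in a single-place change, which the earlier pair could not show. This swap adds a hydrogen-bond donor and removes the chlorine at once, so the step cannot be divided between those two parts. Nothing available explains the step. From the compounds shown here alone, it remains open whether (4-chloro-3-(trifluoromethyl)phenyl)amino, which keeps the chlorine, would match compound 3, and how a methylamino group on that carbonyl carbon would behave.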